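Butyl to methylsulfanyl: an expected flat step in cytotoxicity

The source may hold more compounds than are shown below. What is called first, only, known or untested is meant among the compounds shown, and "the series" means these compounds.

Within the data shown here, compound 1 `CCCCc1ccc(C(=O)/C=C/c2ccc([N+](=O)[O-])s2)cc1` is the only compound that gives a plain number in an ADME assay on Vero cells (Chlorocebus sabaeus) for cytotoxicity, read by resazurin assay, with a stated time of 72 h; on this read-out lower numbers stand for higher toxicity in this test and higher numbers for lower toxicity in this test; in this assay compound 1 gives 81300 nM. Compound 2 `O=C(/C=C/c1ccc([N+](=O)[O-])o1)c1ccc(-c2ccccc2)cc1` reaches only a limit of the assay, > 100000 nM, as the limit of > 100000 nM in this assay, at which 1 of the 2 values shown sits, records. Compound 3 `CSc1ccc(C(=O)/C=C/c2ccc([N+](=O)[O-])s2)cc1` differs from compound 1 by methylsulfanyl in place of butyl on an aromatic carbon. Among the measured compounds shown here, no measured pair shows a step at this place. The author expects the step of a 1.0-fold higher number from compound 1 to compound 3 (0.02 log units; within the scatter) to stay within the usual scatter, with no clear direction. Compound 3 is therefore estimated at 85000 nM, between 35000 nM and 200000 nM, with a fair chance that only a limit is reported.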

Compound 3, half-maximal cytotoxic concentration: > 100000 nM
Compound 3: no number, only a limit; the forecaster's own chance of this, stated with the estimate: 40%; middle value at least 1.1-fold (0.07 log units) from the limit.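

Among these compounds, on this aromatic carbon, methylsulfanyl in place of butyl gives in this assay an at least 1.2-fold higher number from compound 1 to compound 3 (0.08 log units; that floor lies within the scatter), the only step that can be read at this position. That floor leaves the change without a measured size, yet it gives no sign of higher toxicity in this test with methylsulfanyl. Compound 3 gives a limit and not a number, so how far the step reaches stays hidden: the limit of > 100000 nM in this assay, at which 2 of the 3 values shown sit. As far as these compounds go, whether an amine, a carboxylic acid or a longer chain at this position would give a plain number in this assay stays open.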